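Swapping fluoro for methyl on the aniline of compound 3

A few compounds are considered here, and "the series" means these few. Any claim that something is new, unique, unknown or untested is made for them only; others in the source may bear on it.

Measured compounds in a functional assay on NCI-H1975 cells (Homo sapiens) for inhibition, read by MTT assay, with a stated time of 72 h; on this read-out higher numbers stand for weaker inhibition and lower numbers for stronger inhibition:
Compound 1 `O=C(CSc1nc(Nc2ccccc2)c2ccccc2n1)Nc1cccc(Cl)c1` gives 8460 nM.
Compound 2 `C=CC(=O)Nc1cccc(NC(=O)CSc2nc(Nc3ccccc3Br)c3ccccc3n2)c1` gives 19300 nM.
Compound 3 `C=CC(=O)Nc1cccc(NC(=O)CSc2nc(Nc3cccc(F)c3)c3ccccc3n2)c1` gives 2030 nM.

Of the three numbers, compound 3 has the lowest, so it is the strongest inhibitor shown; compound 1 sits closest to it and compound 2 furthest away. Within the data shown here, the only single-point step among the measured compounds is a 9.5-fold lower number from compound 2 to compound 3 (0.98 log units; beyond the scatter), where 3-fluorophenyl replaced 2-bromophenyl on the amine nitrogen.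

Compound 4 `C=CC(=O)Nc1cccc(NC(=O)CSc2nc(Nc3cccc(C)c3)c3ccccc3n2)c1` differs from compound 3 in one place: methyl in place of fluoro on an aromatic carbon. Among the measured compounds shown here, no measured pair shows a fluoro swapped for a methyl, and the step from compound 2 to compound 3 changed both the halogen and its position, so it does not speak directly to this change. For the measured compounds named here, with no guiding step, the expectation for compound 4 is a number near that of compound 3, with a step of a 1.2-fold higher number from compound 3 to compound 4 (0.09 log units; within the scatter) that is likely within the scatter. Compound 4 is therefore estimated at 2500 nM in this assay, ranging from 800 nM to 8000 nM.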

Compound 4, half-maximal inhibitory concentration: 12100 nM
Beside the measured number, compound 4's estimate is 4.8-fold (0.68 log units) below it; measured number above the stated range.
By their numbers in this assay, from the lowest: compound 3; then compounds 1, 4 and 2 (each within the scatter of the next, the first and the last beyond it).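

On this aromatic carbon, exchanging one heavy atom for another is enough to shift the result: in this assay the change from 3-fluorophenyl to 3-methylphenyl gives a 6.0-fold higher number from compound 3 to compound 4 (0.78 log units; beyond the scatter) and neither group carries a hydrogen-bond donor or acceptor. The earlier step changed the halogen and its place together, whereas this one changes the group alone and shows that fluoro and methyl are not interchangeable here, while the listed step of a 1.6-fold lower number from compound 2 to compound 4 (0.20 log units; within the scatter) leaves compound 4 and compound 2 apart by no more than the usual scatter. Nothing measured here gives a reason for the gap between fluoro and methyl.

As far as these compounds go, how chloro, methoxy or an amine on this carbon would compare with fluoro and methyl remains open. So does whether the fluoro-to-methyl change would give a similar step elsewhere on this ring.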